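From 4-methoxybenzyl to 4-chlorobenzyl: one untested change

The compounds below may be only part of what the source reports. "The series", "measured", "known", "first", "only" and "open" are said of these compounds alone.

Within the data shown here, in a functional assay on RS4-11 cells (Homo sapiens) for inhibition, read by CCK-8 assay, with a stated time of 48 h, tested at 20 uM (a lower number here means less inhibition of growth, a higher number more inhibition of growth at the concentration tested), compound 1 `COc1ccc(Cc2nnc(NC(=O)/C(C#N)=C/c3ccccc3OS(=O)(=O)c3ccccc3[N+](=O)[O-])s2)cc1` gives 68% and stands lowest of the three compounds measured so far. Its relatives are compound 2 `COc1ccc(Cc2nnc(NC(=O)/C(C#N)=C/c3ccccc3OS(=O)(=O)c3ccc(Cl)cc3)s2)cc1` with 79% and compound 3 `COc1ccc(Cc2nnc(NC(=O)/C(C#N)=C/c3ccccc3OS(=O)(=O)c3ccc(F)cc3)s2)cc1` with 80% in the same read-out. Both differ from compound 1 only in the group on the sulfonyl sulfur, where 4-chlorophenyl or 4-fluorophenyl replaces 2-nitrophenyl. Those swaps brought a number 11 percentage points higher from compound 1 to compound 2 (beyond the scatter) and a number 12 percentage points higher from compound 1 to compound 3 (beyond the scatter) while a number 1 percentage points higher from compound 2 to compound 3 (within the scatter) comes with fluoro in place of chloro on an aromatic carbon.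

Compound 4 `N#C/C(=C\c1ccccc1OS(=O)(=O)c1ccccc1[N+](=O)[O-])C(=O)Nc1nnc(Cc2ccc(Cl)cc2)s1` keeps the 2-nitrophenyl group of compound 1 and instead carries chloro in place of methoxy on an aromatic carbon so that 4-methoxybenzyl becomes 4-chlorobenzyl. Among the measured compounds shown here, no measured pair changes this place, so the three steps offer only a rough guide to size: single swaps elsewhere moved the number modestly or not beyond the scatter. The expected result is a number 2 percentage points higher from compound 1 to compound 4 (within the scatter) in this assay and this estimate stays within the scatter, with neither direction firmly favoured. For compound 4 the estimated value is 70% with an expected range from 55% to 84% as the likely span.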

Compound 4, percent growth inhibition at one concentration: 65%
For compound 4 the middle estimate is 5 percentage points above the measured one, and the stated range covers the measured number.
By their numbers in this assay, from the lowest: compounds 4 and 1 (each within the scatter of the next); then compounds 2 and 3 (each within the scatter of the next).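

This is the only pair shown that changes the 4-methoxybenzyl group, and in this assay the exchange for 4-chlorobenzyl gives a number 3 percentage points lower from compound 1 to compound 4 (within the scatter). So, with the 2-nitrophenyl group kept on the sulfonyl sulfur, replacing methoxy with chloro on this aromatic carbon does not separate the two compounds, even though two heavy atoms and a hydrogen-bond acceptor leave and one heavy atom with no acceptor enters. No measurement available here explains why the number stays within the scatter for this swap.

Whether the swap would also leave the number within the scatter with the 4-chlorophenyl or 4-fluorophenyl group of compound 2 and compound 3 on the sulfonyl sulfur remains open, as these two compounds are shown only with 4-methoxybenzyl. Also open is how an amine or a carboxylic acid in place of methoxy would read in this assay, since methoxy and chloro are the only two groups shown here at this position.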